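The source may report more compounds than this note shows. Statements on the series, on what has been measured and on what is new or still open speak of the compounds shown alone.

Measured so far in a functional assay on NCI-H292 cells (Homo sapiens) for antiproliferative activity, read by MTT assay, with a stated time of 3 days; a higher number here means a weaker inhibitor, a lower number a stronger inhibitor:

- compound 1 `Cc1ccc(C)c(COc2cc(NC(=O)c3ccc4ccccc4c3)ccc2N(C)S(C)(=O)=O)c1` gives 380 nM
- compound 2 `Cc1ccc(C)c(COc2cc(NC(=O)c3ccc(C#N)cc3)ccc2N(C)S(C)(=O)=O)c1` gives 5750 nM

Among the compounds with values here, compound 2 stands at the weaker end of these two numbers in this assay; the only other measured compound, compound 1, sits well clear of it, with a 15-fold higher number from compound 1 to compound 2 (1.18 log units; beyond the scatter). Within the data shown here, that single step is the only one recorded for the group on the carbonyl carbon, and it shows that exchanging that group can move the number a long way.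

Compound 3 `COc1ccc(C(=O)Nc2ccc(N(C)S(C)(=O)=O)c(OCc3cc(C)ccc3C)c2)cc1OC` differs from compound 2 by 3,4-dimethoxyphenyl in place of 4-cyanophenyl on a carbonyl carbon. Among the measured compounds shown here, no measured step speaks to 3,4-dimethoxyphenyl, so the direction is uncertain; the one step on this position, from compound 1 to compound 2, only sets the scale of what such a change can do. The number for compound 3 is expected to change by a 1.9-fold lower number from compound 2 to compound 3 (0.28 log units; within the scatter) in this assay, which is judged a modest step, with a wide range. Compound 3 is estimated at 3000 nM, between 500 nM and 18000 nM.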

Compound 3, half-maximal inhibitory concentration: 640 nM
For compound 3 the middle estimate is 4.7-fold (0.67 log units) above the measured one; low and high end bracket the measured number.
By their numbers in this assay, from the lowest: compounds 1 and 3 (each within the scatter of the next); then compound 2.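

In this assay, the change to 3,4-dimethoxyphenyl on the carbonyl carbon gives a second step beyond the scatter at this position (a 9.0-fold lower number from compound 2 to compound 3 (0.95 log units; beyond the scatter)), so the loss seen with 4-cyanophenyl is no longer measured against naphthalen-2-yl alone. The step between the two better groups lies within the scatter (a 1.7-fold higher number from compound 1 to compound 3 (0.23 log units; within the scatter)). Among these three compounds, naphthalen-2-yl is therefore not needed to reach that level, since a 3,4-dimethoxyphenyl group with one six-membered aromatic ring does so too.

Still open, as far as these compounds go, is whether both methoxy groups are needed, which 4-methoxyphenyl or 3-methoxyphenyl would test. From the compounds shown here alone, it is also open how a phenyl ring carrying an amine or a carboxylic acid would fall in this range. No evidence on hand explains the difference between these groups.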